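The source may report more compounds than this note shows. Statements on the series, on what has been measured and on what is new or still open speak of the compounds shown alone.

Measured compounds:
compound 1, `C/C=C/C(=O)Nc1ccc(Cn2nc(-c3ccc(Oc4ccccc4)cc3)cc2CO)cc1`: 12200 nM
compound 2, `C/C=C/C(=O)Nc1cccc(Cn2nc(-c3ccc(Oc4ccccc4)cc3)cc2C(=O)OCC)c1`: 7800 nM
compound 3, `C=CC(=O)Nc1cccc(Cn2nc(-c3ccc(Oc4ccccc4)cc3)cc2C(=O)OCC)c1`: 3300 nM

All three were run in a functional assay on Rec1 cells (Homo sapiens) for inhibition, read by luminescence and CellTiter-Glo, with a stated time of 72 h; on this read-out higher numbers stand for weaker inhibition and lower numbers for stronger inhibition. In this assay compound 1 gives the highest of the three numbers; against compound 2 the gap is within the scatter, against compound 3 it lies beyond it. The difference between the core of compound 1 and the core of compound 2 is not broken down here.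

Compounds 2 and 3 share one core and differ only in the amide substituent, (vinyl in place of prop-1-en-1-yl on a carbonyl carbon). This change gives a 2.4-fold lower number from compound 2 to compound 3 (0.37 log units; beyond the scatter).

Compound 4, `C=CC(=O)Nc1ccc(Cn2nc(-c3ccc(Oc4ccccc4)cc3)cc2CO)cc1`, is not yet measured. It stands to compound 1 as compound 3 stands to compound 2: vinyl in place of prop-1-en-1-yl on a carbonyl carbon. The place is the same in both pairs. The change is therefore counted as the same one, made twice among the compounds shown. Among the measured compounds shown here, the expected step for compound 1 to compound 4 is a 2.2-fold lower number from compound 1 to compound 4 (0.35 log units; beyond the scatter), resting on the single measured precedent, a 2.4-fold lower number from compound 2 to compound 3 (0.37 log units; beyond the scatter), and carrying the uncertainty of a step seen once and on a different core. Compound 4 is accordingly expected to give about 5500 nM in this assay, estimated within 2500 nM to 12000 nM.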

Compound 4, half-maximal inhibitory concentration: 3500 nM
Compound 4: middle estimate off by 1.6-fold (0.20 log units), on the high side; measured number inside the range.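

Vinyl in place of prop-1-en-1-yl on a carbonyl carbon gives a 3.5-fold lower number from compound 1 to compound 4 (0.54 log units; beyond the scatter) in this assay. The number falls on both cores, and the two steps do not differ in size beyond the scatter: the same change on two cores in this assay, a 2.4-fold lower number (0.37 log units; beyond the scatter) from compound 2 to compound 3 and a 3.5-fold lower number (0.54 log units; beyond the scatter) from compound 1 to compound 4, 1.5-fold (0.17 log units) apart, within the scatter of two such steps

Within this series, the change therefore carries from one core to the other in direction and, as far as two pairs can tell, in size, but these pairs do not show that it would transfer to any further core, and they do not explain why the number falls.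

The compounds shown leave open whether a lower number needs the double bond at all, since an ethyl group on the carbonyl carbon does not appear among them, and whether a longer chain carrying an amine on the vinyl group would keep the step. From the compounds shown here alone, it also remains open whether the step holds on a core with a carboxylic acid in place of the ethyl ester of compound 3.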